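Acyl variation on the shared core: cyclopentyl to phenethyl

This account rests on a few compounds, and the source may have more. Where it says the series, first, only, none or still open, it means among the compounds named here.

Measured so far:
compound 1 `CCCCC(=O)N1CCC(c2cc(OC)ccc2N)=N1` — 0.18%
compound 2 `COc1ccc(N)c(C2=NN(C(=O)C3CCCC3)CC2)c1` — 1.85%

In an assay on isolated protein for inhibition of Nitric oxide synthase, inducible (Homo sapiens), with a stated time of 30 min, tested at 1 mM (a lower number here means less inhibition, a higher number more inhibition at the concentration tested (going by the name of the read-out)), compound 1 gives 0.18% and compound 2 gives 1.85%. Going by the values given here, the one step measured, a number 1.7 percentage points higher from compound 1 to compound 2 (within the scatter), is within the scatter, so the two compounds are not told apart by this assay; compound 2 merely carries the larger of two numbers that both sit near the bottom of the scale.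

Compound 3 `COc1ccc(N)c(C2=NN(C(=O)CCc3ccccc3)CC2)c1` differs from compound 2 in one place: phenethyl in place of cyclopentyl on a carbonyl carbon. Among the compounds with values here, the only step that bears on an exchange at this carbonyl carbon is the one from butyl to cyclopentyl, and it moved nothing beyond the scatter. Within the data shown here, no measured step shows what a phenethyl group does here, so the expectation rests on the observation that two different acyl groups left the read-out flat. The step from compound 2 to compound 3 is therefore expected to be small, a number 0.4 percentage points lower from compound 2 to compound 3 (within the scatter), with no direction beyond the scatter. Compound 3 is estimated at 1.5%, in the range -5% to 10%.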

Compound 3, a percentage reported as inhibition, at one concentration (the size of the read-out at that concentration, not a potency): 21.2%
Compound 3: the middle estimate sits 19.7 percentage points below what was measured, and the stated range ends below it.
By their numbers in this assay, from the lowest: compounds 1 and 2 (each within the scatter of the next); then compound 3.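

In this assay this position is no longer flat: the change to phenethyl on the carbonyl carbon gives a number 19.4 percentage points higher from compound 2 to compound 3 (beyond the scatter) and so moves the read-out where the exchange of butyl for cyclopentyl did not. Against the open chain the picture is the same, with a number 21 percentage points higher from compound 1 to compound 3 (beyond the scatter) for phenyl in place of ethyl on a saturated chain carbon, two bonds along the chain from a carbonyl carbon. No measurement available here accounts for either step.

Phenethyl differs from cyclopentyl in both ring type and heavy-atom count, so the compounds shown do not separate the aromatic ring from the added atoms. A cyclohexylethyl group would test the ring, while benzyl or 3-phenylpropyl on the same carbonyl carbon would test the length of the chain.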